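Benzylthio for furfurylamino on the purine riboside core

The source may report more compounds than this note shows. Statements on the series, on what has been measured and on what is new or still open speak of the compounds shown alone.

Two compounds have numbers in an assay on isolated protein for binding affinity to Equilibrative nucleoside transporter 1 (Homo sapiens); on this read-out lower numbers stand for stronger inhibition and higher numbers for weaker inhibition. Compound 1 `OC[C@H]1O[C@@H](n2cnc3c(NCc4ccco4)ncnc32)[C@H](O)[C@@H]1O` gives 36300 nM in this assay, the lower of the two numbers. Compound 2 `CSc1ncnc2c1ncn2C1CCCCO1` gives 275000 nM in this assay, a weaker result that lies beyond the scatter from compound 1. Among the measured compounds shown here, no pair of measured compounds differs in a single place, so no step size is established from the data.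

Compound 3 `OC[C@H]1O[C@@H](n2cnc3c(CSc4ccccc4I)ncnc32)[C@H](O)[C@@H]1O` is not yet measured. It differs from compound 1 as follows: a group of 9 heavy atoms (7 carbon, 1 sulfur, 1 iodine; one six-membered aromatic ring of carbon only) in place of a group of 7 heavy atoms (5 carbon, 1 nitrogen, 1 oxygen; one five-membered aromatic ring with 1 hetero atom), on an aromatic carbon. The shared core and the sugar are kept.

For the measured compounds named here, no measured step covers this change, so the expectation is a guess anchored on compound 1. The step from compound 1 to compound 3 in this assay is expected to be a sizeable decrease, a 73-fold lower number from compound 1 to compound 3 (1.86 log units; beyond the scatter). Compound 3 is therefore estimated at 500 nM in this assay, within a wide range from 30 nM to 10000 nM.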

Compound 3, half-maximal inhibitory concentration: 282 nM
Compound 3: the middle estimate sits 1.8-fold (0.25 log units) above what was measured, within the range that was stated.
By their numbers in this assay, from the lowest: compound 3; then compound 1; then compound 2.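

Among the compounds shown here, this is the first single-place step, and it shows that the position on this aromatic carbon strongly affects the result in this assay: with the shared core and the sugar kept, the change gives a 130-fold lower number from compound 1 to compound 3 (2.11 log units; beyond the scatter). The entering group has 0 hydrogen-bond donors against 1 in ((furan-2-yl)methyl)amino, so a donor in this group is not required for the lower number seen with compound 3. No measured data explain the size of this step.

The step changes the linking atoms, the ring and the iodine together, so the share of each remains unresolved. Open questions are whether chlorine or plain hydrogen could replace the iodine, and whether an oxygen or nitrogen link could replace the sulfur while keeping the step.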